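Pyridine to phenyl swap on the cyclopropyl acid arm

The compounds below may be only part of what the source reports. "The series", "measured", "known", "first", "only" and "open" are said of these compounds alone.

Compound 1 `O=C(O)c1cncc(C2CC2c2ccc(OCc3c(-c4c(Cl)cccc4Cl)noc3C3CC3)cc2Cl)c1` gives 14 nM in an assay on HEK293 cells for agonist activity at Bile acid receptor (Homo sapiens) (a lower number here means that less compound is needed, a higher number that more compound is needed for the effect), and stands lowest of the three measured numbers. Compound 3 `CS(=O)(=O)NC(=O)c1ccc(C2CC2c2ccc(OCc3c(-c4c(Cl)cccc4Cl)noc3C3CC3)cc2Cl)cc1` gives 44 nM in this assay, and compound 2 `O=C(O)c1ccc([C@H]2C[C@](O)(c3ccc(OCc4c(-c5c(Cl)cccc5Cl)noc4C4CC4)cc3Cl)C2)cc1` gives 63 nM; both gaps to compound 1 lie beyond the scatter. Compound 4 `O=C(O)c1cccc([C@@H]2C[C@H]2c2ccc(OCc3c(-c4c(Cl)cccc4Cl)noc3C3CC3)cc2Cl)c1` is not yet measured. It differs from compound 1 in one place: 2-(3-carboxyphenyl)cyclopropyl in place of 2-(5-carboxypyridin-3-yl)cyclopropyl on an aromatic carbon. Within the data shown here, the acid-bearing aromatic ring becomes carbon only and two stereocentres are defined; no measured pair shows this step. For compound 4 a step of a 1.4-fold higher number from compound 1 to compound 4 (0.15 log units; within the scatter) is expected in this assay, within the scatter or a little toward a higher number. Compound 4 is therefore estimated at 20 nM, in the range 7 nM to 60 nM.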

Compound 4, half-maximal effective concentration: 29 nM
The estimate for compound 4 lay 1.5-fold (0.16 log units) below the measured number; the measured number falls inside the stated range.
By their numbers in this assay, from the lowest: compound 1; then compounds 4, 3 and 2 (each within the scatter of the next, the first and the last beyond it).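

In this assay, among these compounds, the acid-bearing ring tolerates carbon in place of the ring nitrogen with only a modest cost: a 2.1-fold higher number from compound 1 to compound 4 (0.32 log units; beyond the scatter), the first single-place step. The same step also defines two stereocentres, so it does not separate the ring change from the stereochemistry. Nothing measured here explains the step.

Still open, on these data alone, is how the other cyclopropyl stereoisomers of compound 4 compare. As far as these compounds go, it is also open whether a tetrazole in place of the carboxylic acid would hold the number of compound 4.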